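A few compounds are considered here, and "the series" means these few. Any claim that something is new, unique, unknown or untested is made for them only; others in the source may bear on it.

Measured compounds:
compound 1, `CN(CCO)/N=N/c1ccccc1C(N)=O`, 3.07
compound 2, `CN(C)/N=N/c1ccccc1Cl`, 3.26
compound 3, `CN(C)/N=N/c1ccc(C(N)=O)cc1C(N)=O`, 3.27

In a functional assay on L1210 cells (Mus musculus) for antiproliferative activity (a higher number here means a more potent compound, by a factor of ten per unit of this negative logarithm, a lower number a less potent compound), compound 3 gives the highest of the three numbers shown. Its gaps to compound 2 and to compound 1 are both within the usual scatter, so none of the three can be called more or less potent than another on these data.

Compound 4, `CN(C)/N=N/c1ccccc1C(N)=O`, is not yet measured. It differs from compound 3 in one place: hydrogen in place of carbamoyl on an aromatic carbon. The carbamoyl that leaves sits on an aromatic carbon of a six-membered aromatic ring of carbon only, meta to a carbamoyl group and para to a group of 5 heavy atoms. Going by the values given here, no pair of measured compounds shows this step, so its size is not known from the data. Since the three measured values in this assay lie close together, no step beyond the scatter is expected from compound 3 to compound 4. The account therefore expects a step of a number 0.07 log units lower from compound 3 to compound 4 (within the scatter). Compound 4 is estimated at 3.2, with a range from 2.8 to 3.6.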

Compound 4, logarithm of the reciprocal of the active concentration, log(1/C): 3.31
Compound 4: middle estimate off by 0.11 log units, on the low side; low and high end bracket the measured number.
By their numbers in this assay, from the lowest: compounds 1, 2, 3 and 4 (each within the scatter of the next).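

In this assay, going by these compounds alone, hydrogen in place of carbamoyl on an aromatic carbon, meta to a carbamoyl group and para to a group of 5 heavy atoms, gives a number 0.04 log units higher from compound 3 to compound 4 (within the scatter) as the first measured step at this position, and it lies within the scatter. Carbamoyl in place of chloro on an aromatic carbon gives a number 0.05 log units higher from compound 2 to compound 4 (within the scatter) and also lies within the scatter. Hydrogen in place of hydroxymethyl on a saturated chain carbon bound to an amine nitrogen gives a number 0.24 log units higher from compound 1 to compound 4 (within the scatter) and again stays within the scatter, so none of these three single changes separates the compounds in this assay.

Still open, as far as these compounds go, is whether a carboxylic acid or an amine on that aromatic carbon, or a longer chain on the amine nitrogen, would give a step beyond the scatter. Nothing available bears on what lies behind these small steps.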